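Swapping the aryl group on a cathepsin S inhibitor scaffold

The source may report more compounds than this note shows. Statements on the series, on what has been measured and on what is new or still open speak of the compounds shown alone.

Of the compounds shown here, three sharing one core have been tested in an assay on isolated protein for inhibition of cathepsin S (Homo sapiens); a lower number here means a stronger inhibitor, a higher number a weaker inhibitor. Compound 1 `CC(=O)N1CCc2c(c(-c3ccc(C(F)(F)F)cc3)nn2CC(O)CN2CCC(n3c(O)nc4ccccc43)CC2)C1` gives 100 nM. Compound 2 `Cc1cc(-c2nn(CC(O)CN3CCC(n4c(O)nc5ccccc54)CC3)c3c2CN(S(C)(=O)=O)CC3)ccc1Cl` gives 60 nM, and compound 3 `Cc1cc(-c2nn(CC(O)CN3CCC(n4c(O)nc5ccc(Cl)cc54)CC3)c3c2CN(S(C)(=O)=O)CC3)ccc1Cl` gives 50 nM. Among these three numbers compound 2 stands second highest, with compound 3 nearest and compound 1 furthest, and both of those gaps lie within the usual scatter of this assay, so none of the three can be called stronger or weaker than another on this evidence.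

Compound 4 `CS(=O)(=O)N1CCc2c(c(-c3ccc(C(F)(F)F)cc3)nn2CC(O)CN2CCC(n3c(O)nc4ccccc43)CC2)C1` is not yet measured. Relative to compound 2 it carries 4-(trifluoromethyl)phenyl in place of 4-chloro-3-methylphenyl on an aromatic carbon. For the measured compounds named here, the only step recorded between single-change neighbours is a 1.2-fold lower number from compound 2 to compound 3 (0.08 log units; within the scatter), which concerns a different part of the molecule and points to a small shift at most. Compound 1 already carries the 4-(trifluoromethyl)phenyl group, but it differs from compound 2 in a second place as well, so its value can only be read as a rough hint that this group sits in the same range. On that basis the change is expected to move this assay little, if at all, with a 1.3-fold higher number from compound 2 to compound 4 (0.12 log units; within the scatter). Compound 4 is therefore estimated at 80 nM, with a plausible range from 30 nM to 220 nM.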

Compound 4, half-maximal inhibitory concentration: 50 nM
Compound 4: middle estimate off by 1.6-fold (0.20 log units), on the high side; measured number inside the range.
By their numbers in this assay, from the lowest: compounds 3, 4, 2 and 1 (each within the scatter of the next).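

Replacing 4-chloro-3-methylphenyl with 4-(trifluoromethyl)phenyl on this aromatic carbon of the five-membered ring gives a small step in this assay (a 1.2-fold lower number from compound 2 to compound 4 (0.08 log units; within the scatter)), so with methylsulfonyl held constant on the ring nitrogen, the two aryl groups cannot be told apart. For the compounds shown here, compound 4 also gives the first comparison that isolates the group on that nitrogen: with 4-(trifluoromethyl)phenyl held constant, methylsulfonyl in place of acetyl gives a step that also cannot be read as a real change (a 2.0-fold lower number from compound 1 to compound 4 (0.30 log units; within the scatter)). Neither swap separates the compounds here, and no measurement is available to explain how either group behaves in this assay. What an aryl group carrying an amine or a carboxylic acid, or a plain phenyl ring, would do at this aromatic carbon remains an open question, since both aryl groups shown are halogen-bearing phenyl rings. The ring nitrogen is likewise shown only with acetyl and methylsulfonyl, leaving open how a longer acyl chain or a free amine hydrogen there would compare.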